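Bromophenyl in place of naphthyl on a shared imidazopyrazine core

The source may report more compounds than this note shows. Statements on the series, on what has been measured and on what is new or still open speak of the compounds shown alone.

Of the compounds shown here, three sharing one core have been measured in a functional assay on OVCAR-4 cells (Homo sapiens) for inhibition, read by sulforhodamine B assay, with a stated time of 48 h, tested at 10 uM; on this read-out higher numbers stand for more inhibition at the one concentration tested (going by the name of the read-out) and lower numbers for less inhibition. Compound 1 `COc1ccc(-c2cn3ccnc3c(-c3ccc4ncn(C5CCCCC5)c4c3)n2)cc1` gives 46.4%, compound 2 `O=Cc1ccc(-c2cn3ccnc3c(-c3ccc4ncn(C5CCCCC5)c4c3)n2)cc1` gives 16.9%, and compound 3 `c1ccc2c(-c3cn4ccnc4c(-c4ccc5ncn(C6CCCCC6)c5c4)n3)cccc2c1` gives 19.7%, which places compound 3 second of the three, near compound 2 and well below compound 1. The change 4-bromophenyl in place of naphthalen-1-yl on an aromatic carbon leads to compound 4 `Brc1ccc(-c2cn3ccnc3c(-c3ccc4ncn(C5CCCCC5)c4c3)n2)cc1`. For the measured compounds named here, two measured steps bear on it: a number 26.7 percentage points lower from compound 1 to compound 3 (beyond the scatter), whereas a number 2.8 percentage points higher from compound 2 to compound 3 (within the scatter). Going by these compounds, a para-substituted phenyl thus gave either a clearly higher or an unchanged number, depending on the substituent, and the bromine case is untested. The author therefore expects a small rise, a number 7.3 percentage points higher from compound 3 to compound 4 (within the scatter), and estimates for compound 4 a value of 27%, between 10% and 48%.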

Compound 4, a percentage reported as inhibition, at one concentration (the size of the read-out at that concentration, not a potency): 10.5%
The estimate for compound 4 lay 16.5 percentage points above the measured number, and the stated range covers the measured number.
By their numbers in this assay, from the lowest: compounds 4, 2 and 3 (each within the scatter of the next); then compound 1.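

In this assay a 4-substituted phenyl as such does not keep the level of compound 1, since bromo in place of methoxy gives a number 35.9 percentage points lower from compound 1 to compound 4 (beyond the scatter). With a number 9.2 percentage points lower from compound 3 to compound 4 (within the scatter) and a number 6.4 percentage points lower from compound 2 to compound 4 (within the scatter), compound 4 falls in with compounds 2 and 3, leaving methoxy, in compound 1, as the only group shown here that stands apart at this position. Nothing measured here accounts for this.

Going by these compounds, it remains open whether the level of compound 1 is specific to methoxy. An ethoxy group, a hydroxy group or an amine on the same phenyl ring would test this.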